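This account rests on a few compounds, and the source may have more. Where it says the series, first, only, none or still open, it means among the compounds named here.

Measured in a functional assay on MCF7 cells (Homo sapiens) for inhibition, read by sulforhodamine B assay; on this read-out lower numbers stand for stronger inhibition and higher numbers for weaker inhibition:
- compound 1 `O=C1C=C(Nc2ccccc2F)C(=O)c2c1nc1n2[C@H]2OC[C@@H](O)[C@H]2OC1`: 3640 nM
- compound 2 `O=C1C=C(Nc2ccc(Br)cc2)C(=O)c2c1nc1n2[C@H]2OC[C@@H](O)[C@H]2OC1`: 2580 nM
- compound 3 `CCOc1ccccc1NC1=CC(=O)c2nc3n(c2C1=O)[C@H]1OC[C@@H](O)[C@H]1OC3`: > 4000 nM (a limit, not a number)

Compound 3 is known only as a limit: the limit of > 4000 nM in this assay, at which 1 of the 3 values shown sits.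

Compound 4 `Cc1ccc(NC2=CC(=O)c3nc4n(c3C2=O)[C@H]2OC[C@@H](O)[C@H]2OC4)cc1C` carries 3,4-dimethylphenyl in place of 2-ethoxyphenyl on an amine nitrogen.

Among the compounds with values here, three measured steps bear on this change, all of them swaps on the same aryl group. One is a 1.4-fold lower number from compound 1 to compound 2 (0.15 log units; within the scatter). The other two are an at least 1.0-fold higher number from compound 1 to compound 3 (0.04 log units; that floor lies within the scatter) and an at least 1.5-fold higher number from compound 2 to compound 3 (0.19 log units; that floor lies within the scatter), and both of these are floors only. Within the data shown here, none of the three shows a change beyond the scatter, and no measured compound carries 3,4-dimethylphenyl. The expectation for compound 4 therefore rests on the numbers of compound 1 and compound 2, and no clear step in either direction is expected. The expected step is an at least 1.2-fold lower number from compound 3 to compound 4 (0.09 log units; that floor lies within the scatter), which is not expected to exceed the scatter. For compound 4 the estimated value is 3200 nM, with an expected range of 1500 nM to 6000 nM.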

Compound 4, half-maximal inhibitory concentration: 2080 nM
Compound 4: the middle estimate sits 1.5-fold (0.19 log units) above what was measured; low and high end bracket the measured number.
By their numbers in this assay, from the lowest: compounds 4, 2 and 1 (each within the scatter of the next). At a limit, above all of these: compound 3.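

In this assay, 3,4-dimethylphenyl on the amine nitrogen, an aryl group of carbon only, gives no separation from the two halogen-bearing aryl groups: the readings are a 1.2-fold lower number from compound 2 to compound 4 (0.09 log units; within the scatter) and a 1.8-fold lower number from compound 1 to compound 4 (0.24 log units; within the scatter). Against 2-ethoxyphenyl the change gives only a floor, an at least 1.9-fold lower number from compound 3 to compound 4 (0.28 log units; that floor lies within the scatter), so a real gap between these two aryl groups is neither shown nor excluded. Compound 3 remains a limit and not a number: the limit of > 4000 nM in this assay, at which 1 of the 4 values shown sits.

From the compounds shown here alone, whether any aryl group at this nitrogen moves the value beyond the scatter stays open, since compounds 1, 2 and 4 all lie within the scatter of one another. Also open, going by these compounds, is how an aryl group carrying an amine or a carboxylic acid would read, or a longer alkyl chain in place of the aryl group.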